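Title: Fluoro for methyl on the aryl ring of compound 2

This account rests on a few compounds, and the source may have more. Where it says the series, first, only, none or still open, it means among the compounds named here.

Measured compounds:
- compound 1 `Cc1cc(=O)n(-c2ccc(F)cc2)nc1C(=O)Nc1ccc(Oc2ncnc3sccc23)cc1`: 7050 nM
- compound 2 `Cc1ccc(-n2nc(C(=O)Nc3ccc(Oc4ncnc5sccc45)c(F)c3)c(C)cc2=O)cc1`: > 40000 nM

In a functional assay on A549 cells (Homo sapiens) for cytotoxicity, read by MTT assay, with a stated time of 72 h (a lower number here means a stronger inhibitor, a higher number a weaker inhibitor), compound 1 gives 7050 nM. Compound 2 reaches only the limit of this assay, > 40000 nM, so its value is a bound and not a number. Among the compounds with values here, the two compounds differ in more than one place, and no single-change step between them is available; their values are simply set side by side here, with the limit of > 40000 nM in this assay, at which 1 of the 2 values shown sits, marking where compound 2 sits.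

The next compound, compound 3 `Cc1cc(=O)n(-c2ccc(F)cc2)nc1C(=O)Nc1ccc(Oc2ncnc3sccc23)c(F)c1`, arises from compound 2 by fluoro in place of methyl on an aromatic carbon. The same replacement of 4-methylphenyl by 4-fluorophenyl is the group carried by compound 1, which does give a number in this assay. Within the data shown here, no measured step isolates this change, so its size is not known from the data. Some gain over the limit of compound 2 is expected, yet compound 3 also carries the fluoro on the anilide ring that compound 2 carries and compound 1 does not.

The expected value for compound 3 is 20000 nM, with a range of 6000 nM to 40000 nM. The step this implies is expected to be an at least 2.0-fold lower number from compound 2 to compound 3 (0.30 log units; that floor lies within the scatter). A second reading at the limit is estimated as a fair possibility.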

Compound 3, half-maximal inhibitory concentration: 2620 nM
For compound 3 the middle estimate is 7.6-fold (0.88 log units) above the measured one, and the stated range ends above it.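

In this assay, 4-fluorophenyl in place of 4-methylphenyl gives an at least 15-fold lower number from compound 2 to compound 3 (1.18 log units; beyond the scatter), so the group at this place on the aryl ring can decide whether the series reads as a number at all. That size is only a floor, as compound 2 stands at a limit and not at a number: the limit of > 40000 nM in this assay, at which 1 of the 3 values shown sits. The fluoro in place of hydrogen on the other aromatic ring gives a 2.7-fold lower number from compound 1 to compound 3 (0.43 log units; beyond the scatter), so with 4-fluorophenyl in place that fluoro goes with a lower number, and it does not by itself account for the limit reading of compound 2.

The compounds shown leave open whether 4-methylphenyl costs as much without the second fluoro, so the two changes cannot yet be separated as independent contributions. They also leave open whether the gain belongs to fluoro itself or simply to the loss of methyl, which an unsubstituted phenyl, a chloro or an amine at the same place would help to settle.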